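From Methoxy to Sulfamoyl on Compound 3

The source may report more compounds than this note shows. Statements on the series, on what has been measured and on what is new or still open speak of the compounds shown alone.

Measured in a functional assay on CAPAN-1 cells (Homo sapiens) for cytotoxicity (a higher number here means a weaker inhibitor, a lower number a stronger inhibitor), so far:
- Compound 1 `COc1ccccc1/C=c1\sc2nc(-c3cn(C4CC4)c4cc(N5CCN(C)CC5)c(F)cc4c3=O)nn2c1=O` gives > 10000 nM as a limit
- Compound 2 `CN1CCN(c2cc3c(cc2F)c(=O)c(-c2nc4s/c(=C\c5ccc(C#N)cc5)c(=O)n4n2)cn3C2CC2)CC1` gives > 10000 nM as a limit
- Compound 3 `COc1ccc(/C=c2\sc3nc(-c4cn(C5CC5)c5cc(N6CCN(C)CC6)c(F)cc5c4=O)nn3c2=O)cc1` gives > 10000 nM as a limit

Compound 3 gives > 10000 nM here, which is a limit and not a number. It has no measured neighbour with a real value, and all three compounds share that same limit (the limit of > 10000 nM in this assay, at which 3 of the 3 values shown sit).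

Compound 4 `CN1CCN(c2cc3c(cc2F)c(=O)c(-c2nc4s/c(=C\c5ccc(S(N)(=O)=O)cc5)c(=O)n4n2)cn3C2CC2)CC1` keeps the structure of compound 3 but carries sulfamoyl in place of methoxy on an aromatic carbon, para to a large group (sulfamoyl in place of methoxy on an aromatic carbon).

The closest measured change sits in the same place, and it is a step that the two limits leave unreadable from compound 2 to compound 3 on swapping cyano for methoxy. The two other measured changes are a step that the two limits leave unreadable from compound 1 to compound 2 and a step that the two limits leave unreadable from compound 1 to compound 3 in turn. None of these has a readable size, so they give no direction for the new change in this assay.

Among the compounds with values here, with no step to build on, no change beyond the scatter is expected, and compound 4 will most likely be reported as a limit again. The expected change is a step that the limit leaves unreadable from compound 3 to compound 4 by this estimate. Compound 4 is expected at about 12000 nM with an estimated range of 4000 nM to 30000 nM in this assay if a number is reported at all.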

Compound 4, half-maximal inhibitory concentration: 300 nM
For compound 4 the middle estimate is 40-fold (1.60 log units) above the measured one; measured number outside the range, below it.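

In this assay, this place on the aromatic ring turns out to be able to change the result: sulfamoyl in place of methoxy gives an at least 33-fold lower number from compound 3 to compound 4 (1.52 log units; beyond the scatter), and sulfamoyl in place of cyano gives an at least 33-fold lower number from compound 2 to compound 4 (1.52 log units; beyond the scatter). Cut one bond further out, 4-sulfamoylphenyl in place of 2-methoxyphenyl gives an at least 33-fold lower number from compound 1 to compound 4 (1.52 log units; beyond the scatter), which makes compound 4, at 300 nM, the only one of the four with a real number and the most potent of them. The earlier swaps among methoxy, cyano and the two methoxyphenyl arrangements cannot be read, and each new step also starts from a limit and not from a number, so the true size of the change stays open because of where the other compounds sit: the limit of > 10000 nM in this assay, at which 3 of the 4 values shown sit.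

The compounds shown leave open whether the whole sulfamoyl group is needed, or whether a methylsulfonyl group or a carboxylic acid on the same aromatic carbon would give a similar number. They also leave open whether sulfamoyl would have the same effect on another carbon of this ring.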